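The source may hold more compounds than are shown below. What is called first, only, known or untested is meant among the compounds shown, and "the series" means these compounds.

Measured compounds: compound 1 `COc1ccc2cc(C(C)c3nnc4n3N=C(c3ccc(C)cc3)CS4)ccc2c1` gives 11000 nM in a functional assay on MCF7 cells (Homo sapiens) for inhibition, read by sulforhodamine B assay, with a stated time of 72 h; on this read-out lower numbers stand for stronger inhibition and higher numbers for weaker inhibition; compound 2 `COc1ccc(C2=Nn3c(nnc3C(C)c3ccc4cc(OC)ccc4c3)SC2)cc1` gives 6600 nM; compound 3 `CC(c1ccc(-c2ccccc2)c(F)c1)c1nnc2n1N=C(c1ccc(Br)cc1)CS2` gives 7400 nM.

Compound 2 has the lowest of the three numbers, yet compound 3 and compound 1 both sit within the scatter of it, so no order among them can be claimed. Compound 4 `COc1ccc2cc(C(C)c3nnc4n3N=C(c3ccc(Cl)cc3)CS4)ccc2c1` differs from compound 2 by chloro in place of methoxy on an aromatic carbon. Within the data shown here, the only step that touches this position is a 1.7-fold lower number from compound 1 to compound 2 (0.22 log units; within the scatter), a methoxy for methyl exchange that stayed within the scatter. Among the measured compounds shown here, no measured step covers chloro at this place. The expected step is therefore none beyond the scatter, with a 1.1-fold higher number from compound 2 to compound 4 (0.03 log units; within the scatter), and compound 4 is estimated at 7000 nM, within a range from 3000 nM to 16000 nM.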

Compound 4, half-maximal inhibitory concentration: 10100 nM
For compound 4 the middle estimate is 1.4-fold (0.16 log units) below the measured one; measured number inside the range.
By their numbers in this assay, from the lowest: compounds 2, 3, 4 and 1 (each within the scatter of the next).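

The exchange of 4-methoxyphenyl for 4-chlorophenyl (a 1.5-fold higher number from compound 2 to compound 4 (0.18 log units; within the scatter)) stays within the scatter, as does chloro in place of methyl (a 1.1-fold lower number from compound 1 to compound 4 (0.04 log units; within the scatter)). With the earlier methoxy for methyl step, methyl, methoxy and chloro at this place on the shared core now all lie within the scatter of one another. No available evidence bears on these steps.

As far as these compounds go, what remains open is whether an amine, a carboxylic acid or a longer chain at this place would shift the number beyond the scatter.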